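Hydroxymethyl-Methylpyridine in Place of Methylpyrazole

The source may hold more compounds than are shown below. What is called first, only, known or untested is meant among the compounds shown, and "the series" means these compounds.

In an ADME assay on microsomes from liver (Homo sapiens) for metabolic stability, read by LC-MS, using NADPH, with stated times of 5 min and 30 min, tested at 1 uM (a lower number here means slower removal, a higher number faster removal of the compound), the measured compounds gave:
compound 1 `Cn1cc(-c2cnc(NCc3c(F)ccc4c3CCO4)c3cn[nH]c(=O)c23)cn1`: 21 mL.min-1.g-1
compound 2 `Fc1ccc2c(c1CNc1ncc(Oc3ccccc3)c3nncn13)CCO2`: 18 mL.min-1.g-1
compound 3 `C[C@@H]1CC(=O)N(c2cnc(NCc3c(F)ccc4c3CCO4)n3cnnc23)C1`: < 3 mL.min-1.g-1, which is a limit of the assay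

Compound 1 has the highest of the two numbers, but its nearest neighbour, compound 2, lies within the scatter, so the two cannot be ranked. The value of compound 3 is the limit of < 3 mL.min-1.g-1 in this assay, at which 1 of the 3 values shown sits, and gives no number.

Compound 4 `Cc1nc(CO)ccc1-c1cnc(NCc2c(F)ccc3c2CCO3)c2cn[nH]c(=O)c12` differs from compound 1 in one place: 6-(hydroxymethyl)-2-methylpyridin-3-yl in place of 1-methyl-1H-pyrazol-4-yl on an aromatic carbon. Among the measured compounds shown here, the one measured step, an at least 6.0-fold lower number from compound 2 to compound 3 (0.77 log units; beyond the scatter), concerns a different change on a different core and does not bear on this one. With nothing that speaks to the change, compound 4 is expected to show a step of about a 1.4-fold lower number from compound 1 to compound 4 (0.15 log units; within the scatter), not beyond the scatter. Compound 4 is estimated at 15 mL.min-1.g-1, with a range from 5 mL.min-1.g-1 to 45 mL.min-1.g-1.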

Compound 4, intrinsic clearance in microsomes: 11 mL.min-1.g-1
For compound 4 the middle estimate is 1.4-fold (0.13 log units) above the measured one, within the range that was stated.
By their numbers in this assay, from the lowest: compounds 4, 2 and 1 (each within the scatter of the next). At a limit, below all of these: compound 3.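

In this assay this position, para to a large group, takes 6-(hydroxymethyl)-2-methylpyridin-3-yl in place of 1-methyl-1H-pyrazol-4-yl with a 1.9-fold lower number from compound 1 to compound 4 (0.28 log units; within the scatter). So a six-membered aromatic ring carrying a hydrogen-bond donor gives a number within the scatter of that for the five-membered ring without one. Nothing measured here bears on why the two groups read alike.

Still open, on these data alone, is what the hydroxymethyl and the methyl each contribute alone. Also open, as far as these compounds go, is whether an amine or a carboxylic acid in place of the hydroxymethyl would move the number beyond the scatter.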